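A few compounds are considered here, and "the series" means these few. Any claim that something is new, unique, unknown or untested is made for them only; others in the source may bear on it.

In a functional assay on CEM-DNR-bulk cells (Homo sapiens), read by MTT assay, with a stated time of 72 h (on this read-out lower numbers stand for stronger inhibition and higher numbers for weaker inhibition), compound 1 `COc1ncnc2c1c(-c1cccs1)cn2[C@@H]1O[C@H](CO)[C@@H](O)[C@H]1O` gives 12100 nM. Compound 2 `COc1nc(N)nc2c1c(-c1ccco1)cn2[C@@H]1O[C@H](CO)[C@@H](O)[C@H]1O` reaches only the limit of this assay, > 20000 nM, so its true value is not known, and it sits at the limit of > 20000 nM in this assay, at which 1 of the 2 values shown sits. Compound 3 `COc1nc(N)nc2c1c(-c1cccs1)cn2[C@@H]1O[C@H](CO)[C@@H](O)[C@H]1O` differs from compound 2 by thiophen-2-yl in place of furan-2-yl on an aromatic carbon. Within the data shown here, no measured step with this change exists here, and the exchange of one five-membered ring for another of the same size is expected to give a step in this assay of an at least 1.1-fold lower number from compound 2 to compound 3 (0.04 log units; that floor lies within the scatter), none beyond the usual scatter. Compound 3 is therefore expected to give about 18000 nM, within 8000 nM to 40000 nM.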

Compound 3, half-maximal inhibitory concentration: > 20000 nM
Compound 3 was reported as a limit (the forecaster's own chance of this, stated with the estimate: 50%); middle value at least 1.1-fold (0.04 log units) from the limit.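

Compound 3 is reported in this assay only as a limit of > 20000 nM and not as a number. Compound 2 is also a limit, so the step for thiophen-2-yl in place of furan-2-yl cannot be read, and with either five-membered ring the amino compounds end at the same limit: the limit of > 20000 nM in this assay, at which 2 of the 3 values shown sit. Amino in place of hydrogen on an aromatic carbon gives an at least 1.6-fold higher number from compound 1 to compound 3 (0.21 log units; that floor lies within the scatter) and this is only a floor.

On these data alone, how far the true values of these two compounds lie past the limit stays open. Also open, as far as these compounds go, is whether a phenyl ring or a longer chain on this aromatic carbon, or a methyl group in place of the amino, would give a value inside the range of the assay.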